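This account rests on a few compounds, and the source may have more. Where it says the series, first, only, none or still open, it means among the compounds named here.

Working notes on the series. Two compounds have numbers in an assay on cells (kidney, strain Sprague-Dawley) for displacement of a labelled ligand from Nischarin (Rattus norvegicus), read by scintillation counting, with a stated time of 30 min; a higher number here means a weaker inhibitor, a lower number a stronger inhibitor. Compound 1 `Clc1ccccc1/C=C/C1=NCCN1` carries an exocyclic double bond between its aromatic ring and the shared core; in this assay compound 1 gives 24 nM. Compound 2 `C=CCc1ccccc1NCC1=NCCN1` instead links the aromatic ring to the core through an amine and a saturated chain, and carries an allyl group on the ring; in this assay compound 2 gives 3.98 nM. Compound 2 thus holds the lowest of the two numbers, with compound 1 giving a higher number, a gap that lies beyond the usual scatter. For the measured compounds named here, no single-point step between measured compounds is available, so the effect of trimming the allyl group cannot be read from the measured pair.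

The next compound, compound 3 `Cc1ccccc1NCC1=NCCN1`, differs from compound 2 by hydrogen in place of vinyl on a saturated chain carbon bound to an aromatic carbon; cut one bond further out, allyl becomes methyl. Going by the values given here, with no measured step to lean on, the expectation is a small shift, if any, toward a higher number, within or just beyond the scatter. Compound 3 is expected to give 8 nM, with a range from 2.5 nM to 30 nM. The step this implies, a 2.0-fold higher number from compound 2 to compound 3 (0.30 log units; within the scatter), is an estimate only.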

Compound 3, inhibition constant: 2 nM
Compound 3: the middle estimate sits 4.0-fold (0.60 log units) above what was measured; measured number below the stated range.
By their numbers in this assay, from the lowest: compounds 3 and 2 (each within the scatter of the next); then compound 1.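

In this assay, the change from allyl to methyl, hydrogen in place of vinyl on a saturated chain carbon bound to an aromatic carbon, gives a 2.0-fold lower number from compound 2 to compound 3 (0.30 log units; within the scatter). This first step measured at this place shows that the vinyl, with its double bond outside aromatic rings, can be removed without the number moving beyond the scatter, so compound 2 and compound 3 read as equivalent in this assay and the full allyl group is not required for a number at this level. No measurement on hand offers an explanation for this tolerance.

The compounds shown leave open how far this tolerance extends: whether a hydrogen in place of the methyl, a longer chain such as butyl, or a carboxylic acid in place of the methyl would also keep the number at this level. A single step in a single assay also leaves open whether the same change would read alike on a different linker, such as the exocyclic double bond of compound 1.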